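Compound 2 and a longer ethoxycarbonyl chain

The source may hold more compounds than are shown below. What is called first, only, known or untested is meant among the compounds shown, and "the series" means these compounds.

Measured in a functional assay on the whole organism (strain Hartley) for inhibition, with Cavia porcellus as the target, with stated times of 15 min and 2 min; on this read-out lower numbers stand for an effect already at smaller amounts and higher numbers for an effect only at larger amounts of compound:
Compound 1 `CCCCC1([C@@H](O)/C=C/C2CCC(=O)[C@@H]2CCCCCCC(=O)O)CCC1`: 0.0139 mg/kg
Compound 2 `CCCCC1([C@H](O)/C=C/C2CCC(=O)[C@@H]2CCCCCC(=O)O)CCC1`: 0.032 mg/kg
Compound 3 `CCCCC1([C@H](O)/C=C/C2[C@H](O)CC(=O)[C@@H]2C/C=C\CCCC(=O)O)CCC1`: 0.00154 mg/kg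

Compound 2 has the highest number of the three, and the gaps to compound 1, the nearest, and to compound 3, the furthest, both lie beyond the usual scatter. Compound 4 `CCCCC1([C@H](O)/C=C/C2CCC(=O)[C@@H]2CCCCCCCCC(=O)OCC)CCC1` has not yet been measured. In it, 3-(ethoxycarbonyl)propyl stands in place of carboxy on a saturated chain carbon, five bonds along the chain from a saturated ring carbon (3-(ethoxycarbonyl)propyl in place of carboxy on a saturated chain carbon, five bonds along the chain from a saturated ring carbon). Within the data shown here, none of the measured compounds carries ethoxycarbonyl and no measured step isolates this change, so the expectation is loose and rests on compound 2 at 0.032 mg/kg as its starting point. A moderate move to a higher number is expected in this assay, and the estimated change is a 2.8-fold higher number from compound 2 to compound 4 (0.45 log units; beyond the scatter) as a best guess. For compound 4 the estimated value is 0.09 mg/kg, with an expected range from 0.02 mg/kg to 0.4 mg/kg.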

Compound 4, dose for half-maximal effect: 6.21 mg/kg
The estimate for compound 4 lay 69-fold (1.84 log units) below the measured number; the whole stated range lies below it.
By their numbers in this assay, from the lowest: compound 3; then compound 1; then compound 2; then compound 4.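

In this assay, putting 3-(ethoxycarbonyl)propyl in place of carboxy gives a 190-fold higher number from compound 2 to compound 4 (2.29 log units; beyond the scatter), a large step. Compound 4 is the only compound shown whose chain does not end in carboxy, so this is the first sign that the effect depends strongly on what sits on this saturated chain carbon, five bonds along the chain from a saturated ring carbon. No supporting data bear on why the number rises so far.

The step combines two changes, a longer chain and a carboxy group replaced by an ethyl ester, and the compounds shown cannot separate them. A 3-carboxypropyl group at this place would test the longer chain alone, while ethoxycarbonyl directly in place of carboxy would test the ester alone.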